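Swapping Fluoro for Methyl on the Phenyl Ring

A few compounds are considered here, and "the series" means these few. Any claim that something is new, unique, unknown or untested is made for them only; others in the source may bear on it.

Compound 1 `O=C(O)C(CCC/C=C(/c1cccnc1)c1cccs1)c1ccccc1` and compound 2 `O=C(O)CCCC/C=C(/c1ccc(F)cc1)c1cccnc1` were both tested in an assay (Equus caballus) for inhibition of Thromboxane-A synthase (Homo sapiens), using microsomes; a lower number here means a stronger inhibitor, a higher number a weaker inhibitor. Compound 1 gives 32 nM, while compound 2 gives 83 nM, the higher of the two numbers, and the gap between them lies beyond the usual scatter. Compound 3 `Cc1ccc(/C(=C/CCCCC(=O)O)c2cccnc2)cc1` differs from compound 2 in a single place: methyl in place of fluoro on an aromatic carbon. For the measured compounds named here, no measured pair shows this change, so its size is open. The step of a 1.2-fold lower number from compound 2 to compound 3 (0.07 log units; within the scatter) is expected to stay within the scatter, in either direction. Compound 3 is therefore estimated at 70 nM, with a range from 25 nM to 220 nM.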

Compound 3, half-maximal inhibitory concentration: 85 nM
The estimate for compound 3 lay 1.2-fold (0.08 log units) below the measured number; the measured number falls inside the stated range.
By their numbers in this assay, from the lowest: compound 1; then compounds 2 and 3 (each within the scatter of the next).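

Methyl in place of fluoro on this aromatic carbon, para to a large group, now has a measured size: a 1.0-fold higher number from compound 2 to compound 3 (0.01 log units; within the scatter), in this assay. The 4-fluorophenyl and 4-methylphenyl groups therefore cannot be told apart at this position, so the choice between these two groups leaves the read-out within the scatter. Nothing available explains why the two read alike. From the compounds shown here alone, whether an amine, a methoxy group or a trifluoromethyl group on the same carbon would also stay within the scatter remains open. A shorter chain carrying the carboxylic acid is equally untested here.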